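This account rests on a few compounds, and the source may have more. Where it says the series, first, only, none or still open, it means among the compounds named here.

Compound 2 `O=C1CSC(=O)N1C[C@H]1CN(c2ccc(-n3cc(-c4ccccn4)cn3)c(F)c2)C(=O)O1` holds the highest of the two numbers in an ADME assay on HEK293-A cells (Homo sapiens) for cytotoxicity, read by MTT assay, with a stated time of 48 h; a higher number here means a weaker inhibitor, a lower number a stronger inhibitor: compound 2 gives 283 ug/mL, whereas compound 1 `CCN1CCN(C[C@H]2CN(c3ccc(-n4cc(-c5ccccn5)cn4)c(F)c3)C(=O)O2)CC1` gives 99 ug/mL. Compound 3 `O=CNC[C@H]1CN(c2ccc(-n3cc(-c4ccccn4)cn3)c(F)c2)C(=O)O1` reaches only a limit in this assay, > 400 ug/mL. Compound 4 `O=C1O[C@@H](CNC(=O)C(F)(F)F)CN1c1ccc(-n2cc(-c3ccccn3)cn2)c(F)c1` differs from compound 2 by ((trifluoromethyl)carbonyl)amino in place of 2,4-dioxo-1,3-thiazolidin-3-yl on a saturated chain carbon bound to a saturated ring carbon. Among the compounds with values here, the steps that bear on this change at the same place were a 2.9-fold higher number from compound 1 to compound 2 (0.46 log units; beyond the scatter), an at least 4.0-fold higher number from compound 1 to compound 3 (0.60 log units; beyond the scatter) and an at least 1.4-fold higher number from compound 2 to compound 3 (0.15 log units; that floor lies within the scatter). Compound 4 carries ((trifluoromethyl)carbonyl)amino where compound 3 carries formylamino, and compound 3 is the one at the limit of > 400 ug/mL in this assay, at which 1 of the 3 values shown sits. Compound 4 is therefore expected to show a 1.3-fold higher number from compound 2 to compound 4 (0.13 log units; within the scatter), with an estimate of 380 ug/mL, between 220 ug/mL and 600 ug/mL.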

Compound 4, half-maximal inhibitory concentration: > 400 ug/mL
Compound 4 ended at the assay's limit; the forecaster's own chance of this, stated with the estimate: 55%; middle value at least 1.0-fold (0.02 log units) away from the limit.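

In this assay compound 4 gives a limit, not a number, and a second group now stands there: the limit of > 400 ug/mL in this assay, at which 2 of the 4 values shown sit. Putting ((trifluoromethyl)carbonyl)amino on this saturated chain carbon gives an at least 4.0-fold higher number from compound 1 to compound 4 (0.60 log units; beyond the scatter), while the comparison with the 2,4-dioxo-1,3-thiazolidin-3-yl group gives only an at least 1.4-fold higher number from compound 2 to compound 4 (0.15 log units; that floor lies within the scatter). The step between the two limits cannot be read, so trifluoromethyl in place of hydrogen on the carbonyl carbon has no readable size here.

On these data alone, whether a free amine or a longer acyl chain at this place would also reach the limit remains open.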